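The compounds below may be only part of what the source reports. "The series", "measured", "known", "first", "only" and "open" are said of these compounds alone.

Compounds measured so far:
compound 1, `N=C(N)NCCC[C@@H]1NC(=O)CNC(=O)C[C@@H](C(=O)O)NC(=O)[C@@H](c2ccccc2)NC(=O)CNC1=O`, 19 nM
compound 2, `CC(C)[C@@H]1NC(=O)[C@H](CCCNC(=N)N)NC(=O)CNC(=O)C[C@@H](C(=O)O)NC(=O)[C@@H](c2ccccc2)NC1=O`, 115 nM
compound 3, `N=C(N)NCCC[C@@H]1NC(=O)CNC(=O)C[C@@H](C(=O)O)NC(=O)[C@@H](c2ccccc2)NC(=O)[C@@H]2CCCN2C1=O`, 111 nM

The three cyclic peptides were compared in an assay on a protein complex for binding affinity to integrin alpha-5/beta-1 (Homo sapiens), read by ELISA; on this read-out higher numbers stand for weaker inhibition and lower numbers for stronger inhibition. Compound 1 gives the lowest number of the three; its nearest neighbour is compound 3, which gives 111 nM, and compound 2 sits furthest away. Going by the values given here, the one single-point step in the set, a 6.1-fold higher number from compound 1 to compound 2 (0.78 log units; beyond the scatter), introduces isopropyl in place of hydrogen on a saturated ring carbon of the shared core and shifts the number beyond the scatter toward weaker inhibition.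

Compound 4, `N=C(N)NCCC[C@@H]1NC(=O)CNC(=O)C[C@@H](C(=O)O)NC(=O)[C@@H](c2ccccc2)NC(=O)[C@@H](CCCCN)NC1=O`, has not yet been measured. It differs from compound 1 by 4-aminobutyl in place of hydrogen on a saturated ring carbon. Among the compounds with values here, the change sits on the same ring carbon that carries the isopropyl in compound 2, so the step from compound 1 to compound 2 is the one measured step that bears on it. That step was modest but clearly beyond the scatter, and a substituent of similar or greater size at that carbon is therefore expected to move this assay in the same direction, by a step of about a 4.2-fold higher number from compound 1 to compound 4 (0.62 log units; beyond the scatter). Compound 4 is accordingly estimated at 80 nM, with a likely range from 25 nM to 250 nM.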

Compound 4, half-maximal inhibitory concentration: 8.7 nM
Compound 4: middle estimate off by 9.2-fold (0.96 log units), on the high side; measured number outside the range, below it.
By their numbers in this assay, from the lowest: compound 4; then compound 1; then compounds 3 and 2 (each within the scatter of the next).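

In this assay, 4-aminobutyl in place of hydrogen on this saturated ring carbon gives a 2.2-fold lower number from compound 1 to compound 4 (0.34 log units; beyond the scatter), whereas isopropyl on the same carbon gives a 6.1-fold higher number from compound 1 to compound 2 (0.78 log units; beyond the scatter). This position therefore does not raise the number with every substituent: replacing its hydrogen can move the number in either direction, depending on the group that enters, and both steps are modest though beyond the scatter. Nothing available explains why these two groups move the number in opposite directions.

The compounds shown leave open whether the lower number goes with the amine of the 4-aminobutyl group or with the chain that carries it, a question that a plain butyl chain on this carbon would address. They also leave open how a shorter or longer chain bearing the amine, or a carboxylic acid in place of the amine, would move the number in this series.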